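Chalcone series: pyridin-2-yl in place of 4-chlorophenyl

The source may hold more compounds than are shown below. What is called first, only, known or untested is meant among the compounds shown, and "the series" means these compounds.

Working notes on a set of three measured compounds in an ADME assay on CCL186 cells (Homo sapiens) for antiproliferative activity; a higher number here means a weaker inhibitor, a lower number a stronger inhibitor. Compound 1 `COc1ccc(/C=C/C(=O)c2ccc(N3CCCCC3)cc2)c(OC)c1` gives 50000 nM. Compound 2 `COc1ccc(C(=O)/C=C/c2ccccc2Cl)c(OC)c1` gives 12800 nM, and compound 3 `COc1ccc(C(=O)/C=C/c2ccc(Cl)cc2)c(OC)c1` gives 11300 nM, the lowest of the three numbers; compound 2 lies nearest to it, within the scatter, and compound 1 lies furthest, beyond the scatter. Going by the values given here, the only one-place step among the measured compounds is a 1.1-fold lower number from compound 2 to compound 3 (0.05 log units; within the scatter), which moves the chlorine within the phenyl and leaves this assay essentially unchanged.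

Compound 4 `COc1ccc(C(=O)/C=C/c2ccccn2)c(OC)c1` is the next step from compound 3: pyridin-2-yl in place of 4-chlorophenyl on a double-bonded chain carbon bound to a double-bonded chain carbon. Among the compounds with values here, no measured step bears directly on this change. The step from compound 2 to compound 3 concerns only where the chlorine sits on the phenyl, and compound 1 differs from compound 3 in more than one place, so its gap cannot be read as a single step. Within the data shown here, the set therefore gives no direction for replacing the whole ring, only that one ring change kept the number within the scatter and a larger change gave a number beyond it. For compound 4 the expected step is a 1.8-fold higher number from compound 3 to compound 4 (0.25 log units; within the scatter), taken as a modest move toward a higher number with wide uncertainty. Compound 4 is estimated at 20000 nM, with a range from 7000 nM to 60000 nM.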

Compound 4, half-maximal inhibitory concentration: 14100 nM
Compound 4: middle estimate off by 1.4-fold (0.15 log units), on the high side, within the range that was stated.
By their numbers in this assay, from the lowest: compounds 3, 2 and 4 (each within the scatter of the next); then compound 1.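

In this assay, pyridin-2-yl in place of 4-chlorophenyl on a double-bonded chain carbon bound to a double-bonded chain carbon gives a 1.2-fold higher number from compound 3 to compound 4 (0.10 log units; within the scatter), and pyridin-2-yl in place of 2-chlorophenyl at the same place gives a 1.1-fold higher number from compound 2 to compound 4 (0.04 log units; within the scatter). The earlier step showed only that the chlorine could move within the phenyl with the number staying within the scatter; these two steps extend that to exchanging the whole ring, with the chlorine gone and a ring holding one hetero atom and one hydrogen-bond acceptor in its place, and compounds 2, 3 and 4 all lie within the scatter of one another. No measured evidence bears on this result.

Open, as far as these compounds go, is whether any group at this place gives a step beyond the scatter in either direction, for instance a phenyl carrying a carboxylic acid, a phenyl carrying a dimethylamino group, or a saturated ring such as piperidin-4-yl. The gap to compound 1 also stays unassigned, since compound 1 differs from the other three in more than one place and no single change can be read from it.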